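Chalcone series: methoxy to chloro on the phenyl ring

This account rests on a few compounds, and the source may have more. Where it says the series, first, only, none or still open, it means among the compounds named here.

Measured compounds:
compound 1, `COc1cc(/C=C/C(=O)c2cccc(-n3cc(-c4ccccc4)[nH]c3=O)c2)ccc1O`, 2210 nM in a functional assay on COLO 205 cells (Homo sapiens) for inhibition; a higher number here means a weaker inhibitor of growth, a lower number a stronger inhibitor of growth
compound 2, `COc1ccc(-c2cn(-c3cccc(C(=O)/C=C/c4ccc(O)c(OC)c4)c3)c(=O)[nH]2)cc1`, 6610 nM in this assay

Among the compounds with values here, compound 2 stands at the higher of the two numbers; its only neighbour is compound 1, and the single measured step between them is a 3.0-fold higher number from compound 1 to compound 2 (0.48 log units; beyond the scatter), a change of methoxy in place of hydrogen on an aromatic carbon.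

Compound 3, `COc1cc(/C=C/C(=O)c2cccc(-n3cc(-c4ccc(Cl)cc4)[nH]c3=O)c2)ccc1O`, differs from compound 2 by chloro in place of methoxy on an aromatic carbon. The step of a 3.0-fold higher number from compound 1 to compound 2 (0.48 log units; beyond the scatter) is the only one that bears on this change: it shows what the methoxy group that now leaves was worth, and its departure alone would be expected to return the number toward that of compound 1. What the entering chloro contributes is not shown by any measured pair, so the expectation rests on the methoxy removal. A modest lowering is therefore expected, a 2.6-fold lower number from compound 2 to compound 3 (0.42 log units; beyond the scatter). For compound 3 the estimate is 2500 nM, with a range from 900 nM to 7000 nM.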

Compound 3, concentration for 50% growth inhibition: 3400 nM
The estimate for compound 3 lay 1.4-fold (0.13 log units) below the measured number; low and high end bracket the measured number.
By their numbers in this assay, from the lowest: compounds 1, 3 and 2 (each within the scatter of the next, the first and the last beyond it).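

In this assay the change from 4-methoxyphenyl to 4-chlorophenyl gives a 1.9-fold lower number from compound 2 to compound 3 (0.29 log units; within the scatter), and chloro in place of hydrogen at the same place gives a 1.5-fold higher number from compound 1 to compound 3 (0.19 log units; within the scatter); both steps lie within the scatter. The earlier pair showed only that methoxy at this place separates two numbers beyond the scatter, whereas the chloro compound cannot be told apart from either the hydrogen or the methoxy compound. No data at hand account for this reading.

Open, going by these compounds, is whether an amine, a carboxylic acid or a longer chain such as butoxy at this place would give a step beyond the scatter from compound 1 in either direction. Also open, on these data alone, is whether the chloro step would read the same with another change elsewhere on the shared core.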